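This account rests on a few compounds, and the source may have more. Where it says the series, first, only, none or still open, it means among the compounds named here.

Measured so far in a physicochemical assay for lipophilicity, read by HPLC, at pH 3.0; a lower number here means a more polar compound, a higher number a more lipophilic compound:

compound 1 `NCc1csc(NC(=O)c2cc3ccccc3[nH]2)n1`: 1.1
compound 2 `Cc1csc(NC(=O)c2cc(C(C)(C)C)nn2Cc2ccccc2)n1`: 4.7
compound 3 `NCc1csc(NC(=O)c2ccon2)n1`: 0

Among these three numbers compound 2 stands highest in this assay. Compound 1 lies well below it, and compound 3 lower still, both gaps being clearly beyond the usual scatter of the method. Compound 1 and compound 3 share a different core from compound 2, so their numbers show only where each stands, not what any single change does.

Compound 4 `CC(C)(C)c1cc(C(=O)Nc2nc(CO)cs2)n(Cc2ccccc2)n1` has not yet been measured. It differs from compound 2 in a single place: hydroxy in place of hydrogen on a saturated chain carbon bound to an aromatic carbon. A hydroxy group enters where a hydrogen stood, on a saturated chain carbon bound to an aromatic carbon, so a methyl becomes a hydroxymethyl on the thiazole ring of compound 2.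

Within the data shown here, no measured pair here tracks this exact change, so the size of the step must be expected from the nature of the change alone. The step from compound 2 to compound 4 in this assay is expected to run downward, by a moderate amount beyond the scatter: a number 1.00 log units lower from compound 2 to compound 4 (beyond the scatter). Compound 4 is therefore estimated at 3.7, within a range of 3 to 4.4.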

Compound 4, distribution coefficient: 3.5
Estimate against measurement, compound 4: 0.20 log units above; measured number inside the range.
By their numbers in this assay, from the lowest: compound 3; then compound 1; then compound 4; then compound 2.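

Among these compounds, this pair is the first here that differs in one place only, so it gives the first direct reading of a single change in this assay: with hydroxy in place of hydrogen on a saturated chain carbon bound to an aromatic carbon, the step is a number 1.20 log units lower from compound 2 to compound 4 (beyond the scatter) on the shared core. It shows that this position is not silent in this assay, since turning methyl into hydroxymethyl, with just one added oxygen, moves the number past the usual scatter. Nothing shown here explains the size of this step.

On these data alone, whether an amine, a carboxylic acid or a longer chain at this position would move the number further or less far remains open. This single pair also cannot tell whether the same change elsewhere on the molecule would give a similar step.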